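Swapping pyridazine for pyrimidine on a urea side chain

This account rests on a few compounds, and the source may have more. Where it says the series, first, only, none or still open, it means among the compounds named here.

Measured in an assay on isolated protein for activation of Nicotinamide phosphoribosyltransferase (Homo sapiens); on this read-out lower numbers stand for an effect already at smaller amounts and higher numbers for an effect only at larger amounts of compound:
- compound 1, `CCOC(=O)c1ccc(NC(=O)NCc2c[nH]nn2)cc1`, gives 7750 nM
- compound 2, `CCOC(=O)c1ccc(NC(=O)NCc2ccnnc2)cc1`, gives only a limit of the assay, > 100000 nM
- compound 3, `CCOC(=O)c1ccc(NC(=O)NC(C)c2ccncc2)cc1`, gives 2280 nM

Compound 2 sits at the edge of what this assay reports: its entry is a limit, not a number, namely (the limit of > 100000 nM in this assay, at which 1 of the 3 values shown sits). Among the compounds with values here, of the three measured compounds it is the only one for which no value was obtained.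

The change from compound 2 to compound 4, `CCOC(=O)c1ccc(NC(=O)NCc2ccncn2)cc1`, is pyrimidin-4-yl in place of pyridazin-4-yl on a saturated chain carbon bound to an amide-type nitrogen. Within the data shown here, only one measured step touches this side chain: an at least 12-fold higher number from compound 1 to compound 2 (1.11 log units; beyond the scatter), which shows that moving from the triazole to the pyridazine pushed the compound off the scale. Among the measured compounds shown here, no measured step compares a pyrimidine with a pyridazine, and compound 3 differs in more than one place, so it gives no step.

With compound 2 known only as a limit, the size of the step cannot be fixed, but the pyrimidine is expected to return a measurable number; the estimate for compound 4 is 30000 nM, ranging from 8000 nM to 100000 nM. Compound 4 is expected to show an at least 3.3-fold lower number from compound 2 to compound 4 (0.52 log units; beyond the scatter).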

Compound 4, half-maximal effective concentration: 13600 nM
Estimate against measurement, compound 4: 2.2-fold (0.34 log units) above; the measured number falls inside the stated range.
By their numbers in this assay, from the lowest: compound 3; then compounds 1 and 4 (each within the scatter of the next). At a limit, above all of these: compound 2.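

Pyrimidin-4-yl and pyridazin-4-yl have the same atoms and the same counts of hydrogen-bond donors and acceptors, yet in this assay exchanging one for the other on this chain carbon gives an at least 7.3-fold lower number from compound 2 to compound 4 (0.86 log units; beyond the scatter), so the arrangement of atoms within the ring matters here. As far as these compounds go, the size of that step stays open at one end, as the entry for compound 2 is a limit and not a number: the limit of > 100000 nM in this assay, at which 1 of the 4 values shown sits. Against the triazole, the pyrimidine gives a 1.8-fold higher number from compound 1 to compound 4 (0.24 log units; within the scatter) as its step, so a six-membered aromatic ring at this place does not by itself lose the effect.

The compounds shown leave open whether a pyrazine ring here would behave like the pyrimidine or the pyridazine. Also open, from the compounds shown here alone, is what a methyl branch on the chain carbon, as carried by compound 3, would do with the pyrimidine in place.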